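The compounds below may be only part of what the source reports. "The series", "measured", "known", "first", "only" and "open" are said of these compounds alone.

Measured compounds:
Compound 1, `C#CCN(CCCCOc1ccc2ccc(=O)oc2c1)Cc1ccc(OC)cc1`, in an ADME assay on isolated protein for inhibition of Amine oxidase [flavin-containing] A (Homo sapiens), read by fluorescence and Amplex Red, with stated times of 15 min and 20 min; a lower number here means a stronger inhibitor, a higher number a weaker inhibitor: 54500 nM
Compound 2, `C#CCN(CCCOc1ccc2ccc(=O)oc2c1)Cc1ccc(C(C)C)cc1`, in this assay: 77400 nM

Among the compounds with values here, of the two numbers measured so far, compound 1 gives the lowest, but compound 2 sits close to it, and the gap between compound 1 and compound 2 is within the usual scatter of this assay, so the two cannot be told apart on these numbers. Both are weak inhibitors in this assay.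

Compound 3, `C#CCN(CCCCOc1ccc2ccc(=O)oc2c1)Cc1ccccc1`, has not yet been measured in this assay. It differs from compound 1 in one place: hydrogen in place of methoxy on an aromatic carbon. The methoxy leaves from an aromatic carbon of a six-membered aromatic ring of carbon only, para to a large group, and hydrogen takes its place.

Within the data shown here, no step between measured compounds that differ in one place is available, so the size of this change can only be guessed. Given that both measured compounds are weak and close to each other, a step within or just beyond the scatter is expected in either direction. Compound 3 is therefore estimated at 65000 nM, in the range 20000 nM to 200000 nM, which corresponds to an expected step of a 1.2-fold higher number from compound 1 to compound 3 (0.08 log units; within the scatter).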

Compound 3, half-maximal inhibitory concentration: 89400 nM
Estimate against measurement, compound 3: 1.4-fold (0.14 log units) below, within the range that was stated.
By their numbers in this assay, from the lowest: compounds 1, 2 and 3 (each within the scatter of the next).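

Within the data shown here, the replacement of methoxy by hydrogen on an aromatic carbon, para to a large group, gives the first comparison of compounds that differ in one place. In this assay, the change from 4-methoxybenzyl to benzyl gives a 1.6-fold higher number from compound 1 to compound 3 (0.21 log units; within the scatter), so the two compounds cannot be told apart on these numbers, and inhibition in this weak range does not depend measurably on the methoxy at this place. The data give no measured basis for explaining this result.

The compounds shown leave open whether another group at this same place, such as chlorine, trifluoromethyl, an amine or a carboxylic acid, would give a step beyond the scatter, since methoxy and hydrogen are the only two groups compared here in one step. They also leave open what a longer chain on the ether oxygen, or an amine in place of the propargyl group on the nitrogen, would do to the number in this assay, as no single-place comparison here bears on either part of the structure.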